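Swapping Ethyl for Methoxy on a Potent Kinase Inhibitor

The source may hold more compounds than are shown below. What is called first, only, known or untested is meant among the compounds shown, and "the series" means these compounds.

Compound 1 `CCc1nn2c(O)cc(-c3ccncc3)nc2c1Cc1cccc(Cl)c1Cl`: 0.631 nM
Compound 2 `CCc1nn2c(O)cc(C3CCOCC3)nc2c1Cc1cccc(Cl)c1Cl`: 12.6 nM

In an assay on isolated protein for inhibition of phosphatidylinositol 4,5-bisphosphate 3-kinase catalytic subunit beta isoform (Homo sapiens) (a lower number here means a stronger inhibitor, a higher number a weaker inhibitor), compound 1 gives 0.631 nM, the lowest of the two numbers measured. For the measured compounds named here, the only measured step, a 20-fold higher number from compound 1 to compound 2 (1.30 log units; beyond the scatter), alters a different part of the molecule. Compound 3 `COc1nn2c(O)cc(-c3ccncc3)nc2c1Cc1cccc(Cl)c1Cl` differs from compound 1 by methoxy in place of ethyl on an aromatic carbon. Going by the values given here, no measured step touches this position, so there is nothing to compare the change against directly. With no evidence of a large shift, compound 3 is expected to stay near compound 1, a step of a 1.6-fold higher number from compound 1 to compound 3 (0.20 log units; within the scatter) within the usual scatter. The estimate for compound 3 is 1 nM, ranging from 0.3 nM to 4 nM.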

Compound 3, half-maximal inhibitory concentration: 1.26 nM
Compound 3: the middle estimate sits 1.3-fold (0.10 log units) below what was measured, within the range that was stated.
By their numbers in this assay, from the lowest: compounds 1 and 3 (each within the scatter of the next); then compound 2.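

In this assay, the position on the five-membered ring tolerates this exchange: a 2.0-fold higher number from compound 1 to compound 3 (0.30 log units; within the scatter) shows that methoxy can stand in for ethyl without a change beyond the scatter. Both groups have 2 heavy atoms, but methoxy brings an oxygen and a hydrogen-bond acceptor that ethyl lacks, so at this position that difference leaves the number within the scatter. No measurement shown gives a reason for this result.

As far as these compounds go, whether a propyl chain, an amine or a carboxylic acid would be tolerated here remains open. So does whether methoxy would behave the same way with the oxan-4-yl group of compound 2.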